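This account rests on a few compounds, and the source may have more. Where it says the series, first, only, none or still open, it means among the compounds named here.

Compound 1 `CCC(=O)Nc1ccc(S(=O)(=O)Oc2ccccc2C(C)C)cc1` is the starting point of this small set. In a functional assay on HT-1080 cells (Homo sapiens) for antiproliferative activity, read by sulforhodamine B assay, with a stated time of 48 h (on this read-out lower numbers stand for stronger inhibition and higher numbers for weaker inhibition), compound 1 gives 2100 nM. Compound 2 `CCC(=O)Nc1ccc(S(=O)(=O)Oc2ccccc2I)cc1` differs from it in one place only, (iodo in place of isopropyl on an aromatic carbon), and in this assay compound 2 gives 7200 nM. That single change produced a step of a 3.4-fold higher number from compound 1 to compound 2 (0.54 log units; beyond the scatter), a loss of potency that lies beyond the usual scatter of repeated measurements.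

Compound 3 `CC(C)c1ccccc1OS(=O)(=O)c1ccc(NC(=O)CCCl)cc1` keeps the rest of compound 1 unchanged; the difference between the two cores is chloro in place of hydrogen on a saturated chain carbon, two bonds along the chain from a carbonyl carbon. In this assay compound 3 gives 6500 nM, a step of a 3.1-fold higher number from compound 1 to compound 3 (0.49 log units; beyond the scatter), also beyond the scatter. Compound 3 and compound 2 sit close together, and their two values lie within the scatter of each other, so no order between them can be read.

Compound 4 `O=C(CCCl)Nc1ccc(S(=O)(=O)Oc2ccccc2I)cc1` has not been measured yet. It relates to compound 3 exactly as compound 2 relates to compound 1: the change is iodo in place of isopropyl on an aromatic carbon, the same change at the same kind of place on the same kind of ring. Going by the values given here, the step is expected to be similar in size, about a 3.1-fold higher number from compound 3 to compound 4 (0.49 log units; beyond the scatter), because the one measured instance of this change gave a 3.4-fold higher number from compound 1 to compound 2 (0.54 log units; beyond the scatter). This rests on a single example, so the confidence is limited. Compound 4 is expected to give 20000 nM in this assay, most likely between 8000 nM and 50000 nM.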

Compound 4, half-maximal inhibitory concentration: 4200 nM
The estimate for compound 4 lay 4.8-fold (0.68 log units) above the measured number; the whole stated range lies above it.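

In this assay, putting iodo in place of isopropyl on the chloro-bearing core gives a step of a 1.5-fold lower number from compound 3 to compound 4 (0.19 log units; within the scatter), so compound 3 and compound 4 cannot be told apart, and the loss of potency seen with this change on the core of compound 1 does not carry over: the same change on two cores in this assay, a 3.4-fold higher number (0.54 log units; beyond the scatter) from compound 1 to compound 2 and a 1.5-fold lower number (0.19 log units; within the scatter) from compound 3 to compound 4, 5.3-fold (0.72 log units) apart, beyond the scatter of two such steps

The chloro change behaves the same way, because on the iodo-bearing core it gives a step of a 1.7-fold lower number from compound 2 to compound 4 (0.23 log units; within the scatter), which also leaves the two compounds indistinguishable and differs from its effect on the core of compound 1: the same change on two cores in this assay, a 3.1-fold higher number (0.49 log units; beyond the scatter) from compound 1 to compound 3 and a 1.7-fold lower number (0.23 log units; within the scatter) from compound 2 to compound 4, 5.3-fold (0.72 log units) apart, beyond the scatter of two such steps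

Within these four compounds, then, the effect of each change depends on what the rest of the molecule carries, and the two penalties do not simply add up, but this does not show why, and with only two cores for each change it gives no rule for a further core.

The compounds shown leave open whether a bromo or a methyl group on the same aromatic carbon would follow the isopropyl or the iodo compounds. They also leave open how an amine in place of the chloro, or a longer chain carrying the chloro, would fare on either core.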